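A few compounds are considered here, and "the series" means these few. Any claim that something is new, unique, unknown or untested is made for them only; others in the source may bear on it.

Measured compounds:
- compound 1, `O=C(CCCCCCc1ccccc1)c1ncc(-c2ccc(CO)cn2)o1`: 3.2 nM
- compound 2, `O=C(O)CCCCc1cnc(C(=O)CCCCCCc2ccccc2)o1`: 23.8 nM
- compound 3, `O=C(CCCCCCc1ccccc1)c1ncc(CCCCCO)o1`: 10.1 nM

In an assay for inhibition of Fatty-acid amide hydrolase 1 (Rattus norvegicus), using a Dixon plot (a higher number here means a weaker inhibitor, a lower number a stronger inhibitor), compound 3 stands second highest of the three numbers, between compound 1 and compound 2. The step of a 3.2-fold higher number from compound 1 to compound 3 (0.50 log units; beyond the scatter) and the step of a 2.4-fold lower number from compound 2 to compound 3 (0.37 log units; beyond the scatter) place it there, both beyond the scatter but modest in size.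

Compound 4, `CSCCCCCc1cnc(C(=O)CCCCCCc2ccccc2)o1`, differs from compound 3 by methylsulfanyl in place of hydroxy on a saturated chain carbon, five bonds along the chain from an aromatic carbon. Among the measured compounds shown here, no measured pair shows this particular exchange. The nearest comparison is the step of a 2.4-fold lower number from compound 2 to compound 3 (0.37 log units; beyond the scatter), where the end group of the chain was changed and the number moved only modestly; the step of a 7.4-fold higher number from compound 1 to compound 2 (0.87 log units; beyond the scatter) concerns a different change and bears less directly. With only such modest moves among the chain-terminated compounds, compound 4 is expected to sit close to compound 3, with a step of a 1.1-fold lower number from compound 3 to compound 4 (0.05 log units; within the scatter) of no clear size beyond the scatter. The estimate for compound 4 in this assay is 9 nM, expected to fall between 3 nM and 30 nM.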

Compound 4, inhibition constant: 8.1 nM
The estimate for compound 4 lay 1.1-fold (0.05 log units) above the measured number; the measured number falls inside the stated range.
By their numbers in this assay, from the lowest: compound 1; then compounds 4 and 3 (each within the scatter of the next); then compound 2.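

In this assay, the exchange of hydroxy for methylsulfanyl on a saturated chain carbon, five bonds along the chain from an aromatic carbon, gives a 1.2-fold lower number from compound 3 to compound 4 (0.10 log units; within the scatter), so removing the hydrogen-bond donor at this position leaves no change that can be read. The methylsulfanyl chain also shows the same two gaps as the hydroxy chain, with a 2.9-fold lower number from compound 2 to compound 4 (0.47 log units; beyond the scatter) against the carboxy chain and a 2.5-fold higher number from compound 1 to compound 4 (0.40 log units; beyond the scatter) against the 5-(hydroxymethyl)pyridin-2-yl group. No independent measurement bears on why the two chain ends read alike.

As far as these compounds go, whether an amine at the end of the chain, or a longer chain carrying methylsulfanyl, would read the same remains open. So does whether methylsulfanyl in place of hydroxy would leave the number of compound 1 as little changed.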